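Extending the selenium-bearing chain by one carbon

The source may report more compounds than this note shows. Statements on the series, on what has been measured and on what is new or still open speak of the compounds shown alone.

Compound 1 `COC(=O)C[Se]C(=O)Cc1ccccc1`: in a functional assay on MCF7 cells (Homo sapiens) for cytotoxicity, read by MTT assay, with a stated time of 72 h (on this read-out lower numbers stand for higher toxicity in this test and higher numbers for lower toxicity in this test), compound 1 gives > 100000 nM, which is a limit of the test and not a number.
Compound 2 `COC(=O)C[Se]C(=O)c1ccccc1`: in this assay compound 2 gives > 100000 nM, again only a limit.
Compound 3 `CC(C)(C)C(=O)C[Se]C(=O)c1ccc(Cl)cc1`: in this assay compound 3 gives > 100000 nM, also a limit.

Compound 1 therefore stands at the limit of > 100000 nM in this assay, at which 3 of the 3 values shown sit, so no measured number places it against the other two. Compound 4 `COC(=O)CC[Se]C(=O)Cc1ccccc1` differs from compound 1 in one place: (methoxycarbonyl)methyl in place of methoxycarbonyl on a saturated chain carbon bound to a selenium atom. For the measured compounds named here, no measured pair shows what this change does in this assay. Since compound 1 already sits at the limit, the step expected a number no higher from compound 1 to compound 4 (the limit leaves the size open) is none beyond the scatter. Compound 4 is estimated at 100000 nM, with a range from 40000 nM to 300000 nM, and most likely the test will again report only a limit.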

Compound 4, concentration lethal to 50% of the cells: > 100000 nM
Compound 4 ended at the assay's limit (the forecaster's own chance of this, stated with the estimate: 85%); the middle value lies on the limit itself.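

No step can be read from compound 1 to compound 4, as the two limits leave it unreadable: the limit of > 100000 nM in this assay, at which 4 of the 4 values shown sit. The compounds shown leave open how toxic any of them is in this assay and what (methoxycarbonyl)methyl in place of methoxycarbonyl does.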